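Thiophene-bearing dihydropyrimidinones: from thioester to sec-butyl ester

The source may report more compounds than this note shows. Statements on the series, on what has been measured and on what is new or still open speak of the compounds shown alone.

Measured so far, in an assay on membranes from HeLa cells for displacement of a labelled ligand from adenosine receptor A3 (Homo sapiens), read by scintillation counting, with a stated time of 180 min, tested at 1 uM; a higher number here means more inhibition at the concentration tested (going by the name of the read-out), a lower number less inhibition:
Compound 1, `CC1=C(C(=O)OCc2ccccc2)C(c2cccs2)NC(=O)N1`, gives 8%.
Compound 2, `CC1=C(C(=O)C2CC2)C(c2cccs2)NC(=O)N1`, gives 15%.
Compound 3, `CC1=C(C(=O)SC(C)C)C(c2cccs2)NC(=O)N1`, gives 1%.

Compound 3 stands lowest of the three numbers in this assay; compound 1 is within the scatter of it, and compound 2 lies beyond the scatter above it, seen in the step of a number 14 percentage points lower from compound 2 to compound 3 (beyond the scatter). Compound 4, `CCC(C)OC(=O)C1=C(C)NC(=O)NC1c1cccs1`, differs from compound 3 by sec-butoxy in place of isopropylsulfanyl on a carbonyl carbon. Within the data shown here, no measured step exchanges a sulfanyl for an alkoxy group on that carbonyl, so the only bearing comes from the ester compound 1, whose value in this assay sits within the scatter of compound 3. Compound 4 is therefore expected to show a step of a number 4 percentage points higher from compound 3 to compound 4 (within the scatter), not beyond the scatter. The estimate for compound 4 in this assay is 5%, between -5% and 15%.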

Compound 4, a percentage reported as inhibition, at one concentration (the size of the read-out at that concentration, not a potency): 7%
Estimate against measurement, compound 4: 2 percentage points below; the measured number falls inside the stated range.
By their numbers in this assay, from the lowest: compounds 3, 4, 1 and 2 (each within the scatter of the next, the first and the last beyond it).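

In this assay, among these compounds, sec-butoxy in place of isopropylsulfanyl on a carbonyl carbon gives a number 6 percentage points higher from compound 3 to compound 4 (within the scatter), the first direct reading of an alkoxy group against a sulfanyl group at this place. Sec-butyl in place of benzyl on an oxygen next to a carbonyl group gives a number 1 percentage points lower from compound 1 to compound 4 (within the scatter), and sec-butoxy in place of cyclopropyl on a carbonyl carbon gives a number 8 percentage points lower from compound 2 to compound 4 (within the scatter), so compound 4 lies within the scatter of all three earlier compounds. No evidence is at hand to explain these numbers.

Open, going by these compounds, is how an amide or a carboxylic acid on that carbonyl carbon would read in this assay. Also open, on these data alone, is whether a phenyl ring in place of the thiophene would change these numbers.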